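Growing the para alkyl chain: from isopropyl to butyl

The source may hold more compounds than are shown below. What is called first, only, known or untested is meant among the compounds shown, and "the series" means these compounds.

Measured compounds in an ADME assay on the whole organism with Oryza sativa as the target, tested at 1 uM; on this read-out higher numbers stand for a weaker effect at the one concentration tested and lower numbers for a stronger effect:
compound 1, `CCc1ccccc1NC(=O)N[C@H](C)c1ccccc1`, 100%
compound 2, `CC(C)c1ccc(NC(=O)N[C@H](C)c2ccccc2)cc1`, 79%
compound 3, `CC(C)c1ccc(NC(=O)N[C@@H](C)c2ccccc2)cc1`, 96%

Compound 3 gives the second highest of the three numbers. Its nearest neighbour is compound 1, whose value of 100% sits within the scatter of the value of compound 3. Among the compounds with values here, the only single-point step among the measured compounds is a number 17 percentage points higher from compound 2 to compound 3 (beyond the scatter), which is tied to the fact that compounds 2 and 3 differ only in the configuration as drawn.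

Compound 4, `CCCCc1ccc(NC(=O)N[C@@H](C)c2ccccc2)cc1`, is not yet measured. It differs from compound 3 by butyl in place of isopropyl on an aromatic carbon; the change sits at the place para to a large group on the six-membered aromatic ring of carbon only.

Within the data shown here, none of the measured steps touches this alkyl group: the one step on record concerns configuration alone and gives no guide to swapping isopropyl for butyl. Among the measured compounds shown here, with no comparable step to lean on, the expectation for compound 4 is a value close to that of compound 3, with no step beyond the scatter, namely a number 3 percentage points lower from compound 3 to compound 4 (within the scatter). Compound 4 is therefore estimated at 93% in this assay, with a range from 78% to 100%.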

Compound 4, a percentage reported as activity, at one concentration (the size of the read-out at that concentration, not a potency): 72%
Estimate against measurement, compound 4: 21 percentage points above; measured number below the stated range.
By their numbers in this assay, from the lowest: compounds 4 and 2 (each within the scatter of the next); then compounds 3 and 1 (each within the scatter of the next).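

At the place para to a large group on the six-membered aromatic ring of carbon only, this assay responds to the alkyl group itself: butyl in place of isopropyl gives a number 24 percentage points lower from compound 3 to compound 4 (beyond the scatter). Within the data shown here, until this result the single step on record concerned configuration alone, so this is the first evidence that a change at this place, with the stereocentre drawn the same way, moves the number beyond the scatter, and it moves it towards a stronger effect on this read-out. Nothing on record explains why this particular swap, which leaves no ring, no hydrogen-bond donors or acceptors and no net charge on either side, has this effect.

The compounds shown leave open whether the step follows the length of the chain or the loss of the isopropyl branch, since a propyl, a pentyl or a tert-butyl group at this place would be needed to separate the two. They also leave open how butyl behaves with the stereocentre drawn the other way, and whether an amine or a carboxylic acid would be accepted at this place.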